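Replacing the dichlorophenoxy amide in a melanocortin-4 series

The source may report more compounds than this note shows. Statements on the series, on what has been measured and on what is new or still open speak of the compounds shown alone.

Measured compounds:
- compound 1, `CC(C)C[C@H](N)c1cc(C(F)(F)F)ccc1N1CCN(C(=O)[C@H](C)Cc2ccc(Cl)cc2)CC1`: 31 nM
- compound 2, `CC(C)C[C@H](N)c1cc(C(F)(F)F)ccc1N1CCN(C(=O)COc2cccc(Cl)c2Cl)CC1`: 2500 nM

Within the data shown here, in an assay on HEK293 cells for displacement of a labelled ligand from Melanocortin receptor 4 (Homo sapiens) (a higher number here means a weaker inhibitor, a lower number a stronger inhibitor), compound 2 stands at the high end of the two numbers; the only neighbour, compound 1, sits far below it, and the step of an 81-fold higher number from compound 1 to compound 2 (1.91 log units; beyond the scatter) shows how much the substituent on the carbonyl carbon can move the result. Compound 3, `CC(C)C[C@H](N)c1cc(C(F)(F)F)ccc1N1CCN(C(=O)CCC(=O)N(C)C)CC1`, carries the change ((dimethylcarbamoyl)methyl in place of 2,3-dichlorophenoxy on a saturated chain carbon bound to a carbonyl carbon); the group that leaves holds one six-membered aromatic ring, the group that enters holds no ring. Among the measured compounds shown here, no measured pair mirrors this exchange, so the single step of an 81-fold higher number from compound 1 to compound 2 (1.91 log units; beyond the scatter) is the only guide, and it tells only that this position is sensitive. Compound 3 is therefore expected to shift further in the weaker direction, as the step of a 3.2-fold higher number from compound 2 to compound 3 (0.51 log units; beyond the scatter), with an estimate of 8000 nM and a range from 2000 nM to 30000 nM.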

Compound 3, inhibition constant: > 10000 nM
Compound 3 gave a limit, no number; the forecaster's own chance of this, stated with the estimate: 30%; middle value at least 1.2-fold (0.09 log units) away from the limit.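

In this assay compound 3 gives a limit and not a number: the limit of > 10000 nM in this assay, at which 1 of the 3 values shown sits. Even so, the change from 2,3-dichlorophenoxy to (dimethylcarbamoyl)methyl is readable as an at least 4.0-fold higher number from compound 2 to compound 3 (0.60 log units; beyond the scatter), so this position can lose more than the earlier step showed, and compound 2 was not the floor of the series. The larger step, an at least 320-fold higher number from compound 1 to compound 3 (2.50 log units; beyond the scatter), sets the ring-free group far from the 1-(4-chlorobenzyl)ethyl group; among the three compounds, the two with a six-membered aromatic ring give numbers, and the one with no ring gives only a limit.

The compounds shown leave open how far compound 3 lies past its limit, and whether the loss goes with the missing ring or with the dimethylcarbamoyl group itself. A phenyl ring on the same chain, or an amine or a carboxylic acid at its end, would help separate the two.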